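The source may hold more compounds than are shown below. What is called first, only, known or untested is meant among the compounds shown, and "the series" means these compounds.

In a functional assay on HepG2 cells (Homo sapiens) for antiproliferative activity, read by MTT assay, with a stated time of 72 h (a lower number here means a stronger inhibitor, a higher number a weaker inhibitor), three compounds of one series have been measured. Compound 2 `CCCCCCC#Cc1c(CCCCCC)oc2nc(=O)n(Cc3cn(Cc4ccccc4)nn3)cc12` gives 25800 nM. Compound 1 `CCCCCCC#Cc1c(CCCCCC)oc2nc(=O)n(Cc3cn(-c4ccc(Cl)cc4)nn3)cc12` carries the change (4-chlorophenyl in place of benzyl on an aromatic nitrogen). For compound 1 the assay reports only a limit, > 100000 nM, as the limit of > 100000 nM in this assay, at which 1 of the 3 values shown sits, states. The step of an at least 3.8-fold higher number from compound 2 to compound 1 (0.58 log units; beyond the scatter) therefore shows that this change weakened the inhibitor markedly. Compound 3 `O=c1nc2oc(CCCCl)cc2cn1Cc1cn(Cc2ccccc2)nn1` has a different core; how the core of compound 3 differs from that of compound 2 is not broken down here. In this assay compound 3 gives 27600 nM, which sits close to compound 2.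

Compound 4 `O=c1nc2oc(CCCCl)cc2cn1Cc1cn(-c2ccc(Cl)cc2)nn1` is not yet measured. For the measured compounds named here, it is obtained from compound 3 by the change (4-chlorophenyl in place of benzyl on an aromatic nitrogen), the same change, at the same place, as the one that turned compound 2 into compound 1. Because an at least 3.8-fold higher number from compound 2 to compound 1 (0.58 log units; beyond the scatter) pushed the number up to a limit, compound 4 is expected to move in the same direction from compound 3, with an estimated step of a 3.3-fold higher number from compound 3 to compound 4 (0.51 log units; beyond the scatter). On that basis compound 4 is expected to give about 90000 nM in this assay, likely between 30000 nM and 300000 nM, and quite possibly only a limit again.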

Compound 4, half-maximal inhibitory concentration: 89800 nM
Beside the measured number, compound 4's estimate is 1.0-fold (0.00 log units) above it, and the stated range covers the measured number.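

In this assay, putting 4-chlorophenyl in place of benzyl on the aromatic nitrogen also raises the number on the core of compound 3, with a 3.3-fold higher number from compound 3 to compound 4 (0.51 log units; beyond the scatter), so the change weakens the inhibitor on both cores shown: the same change on two cores in this assay, an at least 3.8-fold higher number (0.58 log units; beyond the scatter) from compound 2 to compound 1 and a 3.3-fold higher number (0.51 log units; beyond the scatter) from compound 3 to compound 4; the limit leaves it open whether they differ. The value of compound 1 is only a limit, > 100000 nM, so the size of the step on that core stays unfixed. The direction of the change therefore carries from one core to the other here, but these results do not show that its size carries over, and two cores are too few to make a rule for the whole series.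

The compounds shown leave open whether the step follows from losing the benzyl carbon link or from gaining the chlorine, a question that plain phenyl and 4-chlorobenzyl on the same nitrogen could separate. They also leave open how an amine or a carboxylic acid on that outer ring would behave on either core.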